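The compounds below may be only part of what the source reports. "The series", "measured", "known", "first", "only" and "open" are said of these compounds alone.

Working notes on the series. Compound 3 `COc1cc(Oc2cccc(Nc3ccccc3)c2)cc(OC)c1CN(C)C` sits at the weak end of what has been measured: in a functional assay on HT-29 cells (Homo sapiens) for inhibition, read by MTT assay, with a stated time of 72 h (a lower number here means a stronger inhibitor, a higher number a weaker inhibitor), compound 3 gives only a limit, > 20000 nM (the limit of > 20000 nM in this assay, at which 1 of the 3 values shown sits). Compound 1 `CNCc1c(OC)cc(Oc2cccc(Nc3ccccc3)c2)cc1OC` gives 7430 nM and compound 2 `COc1cc(Oc2cccc(Nc3ccccc3)c2)cc(OC)c1CNCCNC(C)=O` gives 3960 nM. Compound 4 `COc1cc(Oc2cccc(Nc3ccccc3)c2)cc(OC)c1CNCc1ccc(O)cc1` differs from compound 3 in one place: (4-hydroxybenzyl)amino in place of dimethylamino on a saturated chain carbon bound to an aromatic carbon.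

For the measured compounds named here, two measured steps bear on this change. The step of an at least 5.0-fold higher number from compound 2 to compound 3 (0.70 log units; beyond the scatter) shows that replacing a secondary amine carrying a chain with the dimethylamino group raised the number. The step of an at least 2.6-fold higher number from compound 1 to compound 3 (0.43 log units; beyond the scatter) shows the same direction when the amine nitrogen gained a methyl. Compound 4 reverses this: the amine nitrogen again carries a hydrogen and a larger substituent, the (4-hydroxybenzyl) group, so a lower number than the limit of compound 3 is expected, with the step estimated as an at least 4.0-fold lower number from compound 3 to compound 4 (0.60 log units; beyond the scatter). Compound 4 is therefore expected to give about 5000 nM in this assay, with a range of 1500 nM to 20000 nM, near the values of compound 1 and compound 2.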

Compound 4, half-maximal inhibitory concentration: 2180 nM
Compound 4: middle estimate off by 2.3-fold (0.36 log units), on the high side; the measured number falls inside the stated range.
By their numbers in this assay, from the lowest: compounds 4, 2 and 1 (each within the scatter of the next, the first and the last beyond it). At a limit, above all of these: compound 3.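

In this assay, a (4-hydroxybenzyl)amino group on the saturated chain carbon bound to an aromatic carbon gives a measured value where dimethylamino gave only a limit, an at least 9.1-fold lower number from compound 3 to compound 4 (0.96 log units; beyond the scatter), so the true size of this step remains unknown: the limit of > 20000 nM in this assay, at which 1 of the 4 values shown sits.

The aromatic ring adds to what the secondary amine alone provides, with 4-hydroxyphenyl in place of hydrogen on the chain carbon bound to the amine nitrogen giving a 3.4-fold lower number from compound 1 to compound 4 (0.53 log units; beyond the scatter). By contrast, 4-hydroxyphenyl and acetamidomethyl cannot be separated here, a 1.8-fold lower number from compound 2 to compound 4 (0.26 log units; within the scatter).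

The compounds shown leave open what the hydroxyl contributes, as against a plain benzyl or a 4-methoxybenzyl group on the amine nitrogen. Also open, on these data alone, is how a ring amine such as piperidine or morpholine would compare with dimethylamino at this place.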